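The source may hold more compounds than are shown below. What is called first, only, known or untested is meant among the compounds shown, and "the series" means these compounds.

Compound 1 `O=C(Nc1cccc(-n2cc(-c3ccncc3)c(-c3cc(O)cc(Cl)c3)n2)c1)Nc1ccc(Cl)c(C(F)(F)F)c1` gives 93% in a functional assay on HT-29 cells (Homo sapiens) for inhibition, read by sulforhodamine B assay, with a stated time of 48 h, tested at 0.1 uM; on this read-out higher numbers stand for a weaker effect at the one concentration tested and lower numbers for a stronger effect. Going by the values given here, compound 2 `O=C(Nc1cccc(-n2cc(-c3ccncc3)c(-c3cc(O)cc(Cl)c3)n2)c1)Nc1ccc(Cl)c(Cl)c1` gives 97% in this assay; the one measured step, a number 4 percentage points higher from compound 1 to compound 2 (within the scatter), is chloro in place of trifluoromethyl on an aromatic carbon, and the two numbers sit within the usual scatter of each other. Compound 3 `COc1cc(Cl)cc(-c2nn(-c3cccc(NC(=O)Nc4ccc(Cl)c(C(F)(F)F)c4)c3)cc2-c2ccncc2)c1` differs from compound 1 by methyl in place of hydrogen on an oxygen on an aromatic ring. Among the compounds with values here, no measured step touches this oxygen, so the only measured step carries nothing over to it, and nothing in the data points to a direction. Compound 3 is therefore expected at 93%, between 80% and 102%. The step of no change at the digits printed from compound 1 to compound 3 (within the scatter) is expected to be none beyond the scatter.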

Compound 3, a percentage reported as activity, at one concentration (the size of the read-out at that concentration, not a potency): 94%
For compound 3 the middle estimate is 1 percentage points below the measured one; the range from low to high includes it.
By their numbers in this assay, from the lowest: compounds 1, 3 and 2 (each within the scatter of the next).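

Hydroxy to methoxy is the first change at this oxygen with a reading, and it gives a number 1 percentage points higher from compound 1 to compound 3 (within the scatter) in this assay at the one concentration tested. The hydroxy hydrogen is therefore not needed to hold the number where compound 1 has it, and this read-out does not separate hydroxy from methoxy at this position. Nothing available bears on why this is so.

Going by these compounds, whether a longer chain on this oxygen, such as ethoxy or benzyloxy, would shift the number remains open. So does the effect of an amine or a carboxylic acid in place of the hydroxy.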